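Hydroxy for a disulfide on a naphthoquinone selenide

The source may hold more compounds than are shown below. What is called first, only, known or untested is meant among the compounds shown, and "the series" means these compounds.

Measured compounds:
Compound 1, `CC1=C([Se]CC(OC(=O)CC[Se]c2ccccc2)C(=O)NCCCCCC(=O)OCc2ccccc2)C(=O)c2ccccc2C1=O`, 4000 nM in a functional assay on A498 cells (Homo sapiens) for cytotoxicity, read by MTT assay, with a stated time of 24 h; on this read-out lower numbers stand for stronger inhibition and higher numbers for weaker inhibition.
Compound 2, `CC1=C([Se]CC(OC(=O)[C@@H](CSSC(C)(C)C)NC(=O)OC(C)(C)C)C(=O)NC(C)(C)C)C(=O)c2ccccc2C1=O`, 5000 nM in this assay.
Compound 3, `CC1=C(SCCC(=O)OC(C[Se]C2=C(C)C(=O)c3ccccc3C2=O)C(=O)NC(C)(C)C)C(=O)c2ccccc2C1=O`, 3000 nM in this assay.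

All three numbers sit within the usual scatter of one another, so compound 2 stands among them without a real gap to compound 1 or compound 3. Compound 4, `CC1=C([Se]CC(OC(=O)[C@@H](CO)NC(=O)OC(C)(C)C)C(=O)NC(C)(C)C)C(=O)c2ccccc2C1=O`, has not yet been measured. It differs from compound 2 in one place: hydroxy in place of ((tert-butyl)sulfanyl)sulfanyl on a saturated chain carbon, two bonds along the chain from an amide-type nitrogen and a carbonyl carbon. Among the measured compounds shown here, no step between measured compounds speaks to this kind of change, and the three values give no hint that a side-chain alteration of this sort moves the number far. The step from compound 2 to compound 4 in this assay is therefore expected to be small, a 1.2-fold higher number from compound 2 to compound 4 (0.08 log units; within the scatter), with no direction beyond the scatter. For compound 4 the estimate in this assay is 6000 nM, between 2500 nM and 15000 nM.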

Compound 4, half-maximal inhibitory concentration: 5000 nM
Compound 4: middle estimate off by 1.2-fold (0.08 log units), on the high side; measured number inside the range.
By their numbers in this assay, from the lowest: compounds 3, 1, 2 and 4 (each within the scatter of the next).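

Replacing ((tert-butyl)sulfanyl)sulfanyl with hydroxy on this saturated chain carbon gives no change at the digits printed from compound 2 to compound 4 (within the scatter) in this assay, so the disulfide is not needed for the activity compound 2 shows here. Among the compounds shown here, this is the first direct reading of a single change, since none of the earlier compounds formed a pair differing in one place. Nothing shown explains why the number holds.

From the compounds shown here alone, it remains open whether an amine, a carboxylic acid or a longer chain at this carbon would also leave the number in place. The same swap on a different core is also untested by the compounds shown.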